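From Nitro to Bromo on Compound 1

This account rests on a few compounds, and the source may have more. Where it says the series, first, only, none or still open, it means among the compounds named here.

In a functional assay on PC-3 cells (Homo sapiens) for antiproliferative activity, read by MTT assay, with a stated time of 48 h (on this read-out lower numbers stand for stronger inhibition and higher numbers for weaker inhibition), compound 1 `COc1ccc(CN(C(=O)CSc2nc3ccccc3s2)c2cc(OC)c(OC)c(OC)c2)cc1[N+](=O)[O-]` gives 26500 nM, the highest number of the three measured compounds, which makes it the weakest inhibitor among them. Compound 3 `COc1ccc(CN(C(=O)CSc2nc3c(C)cccc3s2)c2cc(OC)c(OC)c(OC)c2)cc1O` comes nearest at 12300 nM, and compound 2 `COc1ccc2nc(SCC(=O)N(Cc3ccc(OC)c(O)c3)c3cc(OC)c(OC)c(OC)c3)sc2c1` lies furthest away at 4110 nM.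

The next structure, compound 4 `COc1ccc(CN(C(=O)CSc2nc3ccccc3s2)c2cc(OC)c(OC)c(OC)c2)cc1Br`, has not yet been measured. It differs from compound 1 in a single place: bromo in place of nitro on an aromatic carbon. The swap sits ortho to a methoxy group, so 4-methoxy-3-nitrobenzyl becomes 3-bromo-4-methoxybenzyl.

Direct evidence for this swap is missing. For the measured compounds named here, the only measured single-place step is a 3.0-fold higher number from compound 2 to compound 3 (0.48 log units; beyond the scatter), a modest change on the far side of a sulfur, not at the position that changes here. Compound 2 and compound 3 each differ from compound 1 in more than one place, and neither carries bromo, so they offer only a loose hint. Compound 1 stands at 26500 nM and both of the others give lower numbers, which points to a small expected move downward, about the size of the scatter. The expected change is a 1.9-fold lower number from compound 1 to compound 4 (0.28 log units; within the scatter). For compound 4 the estimate is 14000 nM, with an expected range from 5000 nM to 35000 nM.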

Compound 4, half-maximal inhibitory concentration: 16000 nM
For compound 4 the middle estimate is 1.1-fold (0.06 log units) below the measured one, within the range that was stated.
By their numbers in this assay, from the lowest: compound 2; then compounds 3, 4 and 1 (each within the scatter of the next, the first and the last beyond it).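

In this assay, for the compounds shown here, this swap gives the first direct reading at this position: a 1.7-fold lower number from compound 1 to compound 4 (0.22 log units; within the scatter). The read-out therefore does not separate nitro from bromo here, even though the change replaces a group of 3 heavy atoms and 2 hydrogen-bond acceptors with a single bromine atom that has no hydrogen-bond acceptors, so at least these two quite different groups can sit on this aromatic carbon with no change beyond the usual scatter. Nothing measured here bears on the reason for this result.

What the compounds shown leave open is how far that holds for other kinds of group at the same place, such as an amine or a carboxylic acid, which would show whether this position responds to any exchange at all or only looks flat for this pair. From the compounds shown here alone, it also remains open whether bromo would read the same way when the other end of the molecule carries the changes seen in compound 2 and compound 3, since the present pair shares the unsubstituted core of compound 1.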